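Swapping phenoxy for a methyl-oxadiazole

The compounds below may be only part of what the source reports. "The series", "measured", "known", "first", "only" and "open" are said of these compounds alone.

compound 1 (`Fc1cccc(-c2nc3cccnc3n2C2CCCCC2)c1`) 342 nM
compound 2 (`c1ccc(Oc2ccc(-c3nc4cccnc4n3C3CCCC3)cc2)cc1`) > 10000 nM (a limit, not a number)

In a functional assay on MDA-MB-231 cells (Homo sapiens) for cytotoxicity, read by MTT assay, with a stated time of 24 h (on this read-out higher numbers stand for weaker inhibition and lower numbers for stronger inhibition), compound 1 gives 342 nM as a true measured number. Compound 2 gives > 10000 nM and this is a limit of the assay, not a number. So compound 2 has no exact value, and the two compounds differ in more than one place, which means no single change can be read from them.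

Compound 3 (`Cc1nnc(-c2ccc(-c3nc4cccnc4n3C3CCCC3)cc2)o1`) keeps the rest of compound 2 but carries 5-methyl-1,3,4-oxadiazol-2-yl in place of phenoxy on an aromatic carbon, para to a large group (5-methyl-1,3,4-oxadiazol-2-yl in place of phenoxy on an aromatic carbon). For the measured compounds named here, no measured step shows what this exchange does in this assay so any forecast is rough. Compound 1 at 342 nM shows that a related compound can give a measurable value, so a moderate move toward lower numbers is expected. Compound 3 may also stay at the limit. The expected change is an at least 4.0-fold lower number from compound 2 to compound 3 (0.60 log units; beyond the scatter) as an estimate. Compound 3 is expected at 2500 nM (estimated range 400 nM to 15000 nM).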

Compound 3, half-maximal inhibitory concentration: 21 nM
Beside the measured number, compound 3's estimate is 120-fold (2.08 log units) above it, and the stated range ends above it.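

In this assay, placing 5-methyl-1,3,4-oxadiazol-2-yl instead of phenoxy on this aromatic carbon gives an at least 470-fold lower number from compound 2 to compound 3 (2.67 log units; beyond the scatter), the only step among the compounds shown that can be read as a single change. The size of this step rests on a limit for compound 2, not on a number: the limit of > 10000 nM in this assay, at which 1 of the 3 values shown sits. The exchange replaces a six-membered aromatic ring of carbon only with a five-membered aromatic ring with 3 hetero atoms, and it shows that the group at this place, para to a large group, can take a compound from a limit to a true measured value.

The compounds shown do not separate what matters within this exchange, since the ring size, the hetero atoms and the number of hydrogen-bond acceptors all change together. From the compounds shown here alone, it also remains open whether an amine or a carboxylic acid at the same place would give a low number like that of compound 3, or whether the methyl group on the oxadiazole is needed at all.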